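This account rests on a few compounds, and the source may have more. Where it says the series, first, only, none or still open, it means among the compounds named here.

Of the compounds shown here, three of this set have been measured in a functional assay on SF-295 cells (Homo sapiens) for cytotoxicity, read by sulforhodamine B assay, with a stated time of 48 h; a lower number here means a stronger inhibitor of growth, a higher number a weaker inhibitor of growth. Compound 3 `ClCc1ccc(Cn2cnc3c(Cl)nc(Cl)nc32)cc1` gives 19500 nM. Compound 1 `Nc1nc(Cl)c2ncn(Cc3ccc(CCl)cc3)c2n1` gives 27500 nM. Compound 2 `ClCc1cccc(Cn2cnc3c(Cl)nc(Cl)nc32)c1` gives 17000 nM. For the measured compounds named here, all three numbers lie within the usual scatter of one another, so no compound of the three can be set apart from the others on these data alone.

Compound 3 and compound 1 differ in one place only: amino in place of chloro on an aromatic carbon. This change gave a 1.4-fold higher number from compound 3 to compound 1 (0.15 log units; within the scatter). Compound 2 and compound 3 carry the same atoms joined differently; the difference between the two cores is not broken down here.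

Compound 4 `Nc1nc(Cl)c2ncn(Cc3cccc(CCl)c3)c2n1` has not yet been measured in this assay. It differs from compound 2 by amino in place of chloro on an aromatic carbon. The place at which this change is made is described in exactly the same words as for the pair of compound 3 and compound 1, so the change is the same one, made a second time on the other core. Because that same change once gave a 1.4-fold higher number from compound 3 to compound 1 (0.15 log units; within the scatter), a step of similar and small size is expected from the second pair as well. The step expected for compound 4 is a 1.4-fold higher number from compound 2 to compound 4 (0.15 log units; within the scatter). On that basis compound 4 is estimated to give 24000 nM, with the likely range running from 12000 nM to 48000 nM.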

Compound 4, concentration for total growth inhibition: 14500 nM
Compound 4: middle estimate off by 1.7-fold (0.22 log units), on the high side; the range from low to high includes it.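

In this assay, amino in place of chloro on an aromatic carbon gave a 1.2-fold lower number from compound 2 to compound 4 (0.07 log units; within the scatter), so on this second core the change again stays inside what repeated measurements would scatter by. Set beside the first pair, the two steps cannot be told apart: the same change on two cores in this assay, a 1.4-fold higher number (0.15 log units; within the scatter) from compound 3 to compound 1 and a 1.2-fold lower number (0.07 log units; within the scatter) from compound 2 to compound 4, 1.7-fold (0.22 log units) apart, within the scatter of two such steps. This shows that, across these two cores, the change carries over as a step too small to read, but it does not show that the change has a direction of its own, that the two cores respond differently, despite the opposite signs of the two steps, or that the same would hold on any core outside these four compounds.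

The compounds shown leave open what other groups would do at this place between two ring nitrogen atoms, such as a methoxy group, a dimethylamino group or a longer amine chain, since only chloro and amino appear there. They also leave open how the numbers in this assay would respond if the chloromethyl group carried by all four compounds gave way to a plain methyl or a hydroxymethyl group.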